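A Cyclised Sulfonamide Substituent on the Shared Core

The compounds below may be only part of what the source reports. "The series", "measured", "known", "first", "only" and "open" are said of these compounds alone.

Compound 1 `COCCN(C)S(=O)(=O)c1ccc(C)c(C#Cc2cc(Cl)ccc2OCC(=O)O)c1` and compound 2 `CC1(C)C(=O)c2ccc(C#Cc3cc(Cl)ccc3OCC(=O)O)cc2S1(=O)=O` have both been tested in an assay on CHO cells for displacement of a labelled ligand from prostaglandin D2 receptor 2 (Homo sapiens), read by scintillation counting; a lower number here means a stronger inhibitor, a higher number a weaker inhibitor. Compound 1 gives 4.1 nM, while compound 2 gives 31 nM; compound 1 thus holds the lower of the two numbers, and its gap to compound 2 lies beyond the usual scatter. Compound 3 `Cc1ccc(S(=O)(=O)N2CCOCC2)cc1C#Cc1cc(Cl)ccc1OCC(=O)O` has not yet been measured. It differs from compound 1 in one place only: morpholin-4-yl in place of (2-methoxyethyl)(methyl)amino on a sulfonyl sulfur. The group that leaves and the group that enters are alike in what is counted, the new one simply closing into a ring. Going by the values given here, no pair of measured compounds shows this particular change, so no measured step can be consulted for it. The expected step from compound 1 to compound 3 is a 1.5-fold higher number from compound 1 to compound 3 (0.17 log units; within the scatter), small and probably within the scatter. Compound 3 is therefore estimated at about 6 nM in this assay, with a range from 2 nM to 20 nM.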

Compound 3, inhibition constant: 3.6 nM
Compound 3: the middle estimate sits 1.7-fold (0.22 log units) above what was measured, and the stated range covers the measured number.
By their numbers in this assay, from the lowest: compounds 3 and 1 (each within the scatter of the next); then compound 2.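

Going by these compounds alone, on the sulfonyl sulfur, closing (2-methoxyethyl)(methyl)amino into morpholin-4-yl gives a 1.1-fold lower number from compound 1 to compound 3 (0.06 log units; within the scatter) in this assay and is the first step read at this position. With the same counted atoms on either side of the step, the open chain and the ring cannot be told apart by their numbers, so at this position in the shared core, closing the ring leaves the reading level. Nothing on hand accounts for this result or gives a measured property of either group. The compounds shown leave open whether a piperidin-1-yl or azetidin-1-yl ring on the sulfonyl sulfur would read alike, which would show whether the ring oxygen matters. They also leave open how a piperazin-1-yl group, with its second ring nitrogen, or a longer chain ending in a carboxylic acid would read there.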